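Swapping a Hydroxy for Ethyl on a Sulfonamide Chain

The source may report more compounds than this note shows. Statements on the series, on what has been measured and on what is new or still open speak of the compounds shown alone.

Compound 1 `CC[C@@H]1C(=O)N(C)c2cnc(Nc3ccc(S(=O)(=O)NCCO)cc3)nc2N1C1CCCC1`: 278 nM
Compound 2 `CC[C@@H]1C(=O)N(C)c2cnc(-n3ccc4cc(C(=O)NC(C)C)ccc43)nc2N1C1CCCC1`: 1660 nM
Compound 3 `CCC1C(=O)N(C)c2cnc(-n3ccc4cc(C(=O)NC(C)C)ccc43)nc2N1c1ccn(C)n1`: 6740 nM

All three were tested in a functional assay on Huh-7 cells (Homo sapiens) for antiproliferative activity, read by CCK-8 assay, with a stated time of 72 h; a higher number here means a weaker inhibitor of growth, a lower number a stronger inhibitor of growth. Compound 1 gives the lowest number of the three; compound 2 sits well above it and compound 3 higher still, both gaps beyond the usual scatter. Compound 4 `CCCCNS(=O)(=O)c1ccc(Nc2ncc3c(n2)N(C2CCCC2)[C@H](CC)C(=O)N3C)cc1` has not yet been measured. It differs from compound 1 in a single place: ethyl in place of hydroxy on a saturated chain carbon, two bonds along the chain from a sulfonamide nitrogen. Among the measured compounds shown here, no pair of measured compounds carries this change, so there is no measured step to lean on. In this assay the expected step from compound 1 to compound 4 is small, a 1.2-fold higher number from compound 1 to compound 4 (0.06 log units; within the scatter), lying within the scatter. Compound 4 is therefore estimated at about 320 nM, with a likely range from 110 nM to 950 nM.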

Compound 4, concentration for 50% growth inhibition: 225 nM
Estimate against measurement, compound 4: 1.4-fold (0.15 log units) above, and the stated range covers the measured number.
By their numbers in this assay, from the lowest: compounds 4 and 1 (each within the scatter of the next); then compound 2; then compound 3.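

In this assay the swap gives a 1.2-fold lower number from compound 1 to compound 4 (0.09 log units; within the scatter), so the two compounds cannot be told apart. At this place on the chain, then, hydroxy, with one hydrogen-bond donor and one acceptor, can give way to ethyl, with neither, without a measurable change in growth inhibition. No supporting measurement is available to explain this result. On these data alone, it remains open whether an amine or a carboxylic acid at the same place would also leave the number within the scatter. As far as these compounds go, a longer chain, such as hexyl, is equally open.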